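Swapping methyl for bromo on an inactive dichloro analogue

This account rests on a few compounds, and the source may have more. Where it says the series, first, only, none or still open, it means among the compounds named here.

Measured so far:
Compound 1, `Clc1ccc(Nc2nccc(-c3ccc(Br)cc3)n2)cc1`, gives 4180 nM.
Compound 2, `Cc1ccc(-c2ccnc(Nc3ccc(Cl)cc3Cl)n2)cc1`, gives > 1000000 nM.

Both compounds were tested in a functional assay on MCF7 cells (Homo sapiens) for antiproliferative activity, read by MTT assay; on this read-out higher numbers stand for weaker inhibition and lower numbers for stronger inhibition. Compound 1 gives 4180 nM. For compound 2 the read-out is only a limit, > 1000000 nM, so compound 2 stands at the weak end of the two numbers shown, where the only evidence is the limit of > 1000000 nM in this assay, at which 1 of the 2 values shown sits. Compound 3, `Clc1ccc(Nc2nccc(-c3ccc(Br)cc3)n2)c(Cl)c1`, has not yet been measured. It differs from compound 2 by bromo in place of methyl on an aromatic carbon. Compound 3 carries the bromo group found in compound 1 together with the dichloro pattern of compound 2. Going by the values given here, no measured step connects these compounds, so the estimate rests on both neighbours. Compound 3 is expected to land between them, with the expected step of an at least 25-fold lower number from compound 2 to compound 3 (1.39 log units; beyond the scatter) toward stronger inhibition. The estimate for compound 3 is 40000 nM, within a range from 4000 nM to 1000000 nM.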

Compound 3, half-maximal inhibitory concentration: 2490 nM
For compound 3 the middle estimate is 16-fold (1.21 log units) above the measured one; the measured number lies below the stated range.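

In this assay, the change from 4-methylphenyl to 4-bromophenyl gives an at least 400-fold lower number from compound 2 to compound 3 (2.60 log units; beyond the scatter), showing that this single position, para to a large group, can decide between measurable activity and none within the tested range. The read-out for compound 2 is a limit, so that step gives only a minimum size: the limit of > 1000000 nM in this assay, at which 1 of the 3 values shown sits. With bromo in place, adding a second chloro gives a 1.7-fold lower number from compound 1 to compound 3 (0.22 log units; within the scatter), a step within the scatter, so the dichloro pattern alone does not stop these compounds from acting.

As far as these compounds go, only methyl and bromo appear at this position, so it stays open how fluoro, methoxy or an amine would read there. Going by these compounds alone, also open is how methyl would read alongside the single chloro of compound 1.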